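The source may hold more compounds than are shown below. What is called first, only, known or untested is meant among the compounds shown, and "the series" means these compounds.

Measured compounds:
- compound 1, `Oc1cccc(-c2cc(-c3ccc(Cl)cc3)nc(-c3ccsc3)c2)c1`, 11500 nM
- compound 2, `Oc1ccc(-c2cc(-c3ccncc3)nc(-c3ccc(Cl)cc3)c2)cc1`, "not determined" (no result reported)
- compound 3, `Oc1ccc(-c2cc(-c3ccc(Cl)cc3)nc(-c3cccnc3)c2)cc1`, 29300 nM

In a functional assay on T47D cells (Homo sapiens) for cytotoxicity, read by CCK-8 assay and cell counting, with a stated time of 2 days (on this read-out lower numbers stand for stronger inhibition and higher numbers for weaker inhibition), compound 1 gives 11500 nM. Compound 2 was taken into the same series but in this assay compound 2 gives "not determined" (no result reported). In this assay compound 3 gives 29300 nM, the highest of the two numbers that are known; its nearest neighbour is compound 1, whose lower number lies beyond the scatter of repeated measurements. No two of the measured compounds differ in only one place, so no single step can be read off directly.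

Compound 4, `Oc1ccc(-c2cc(-c3ccc(Cl)cc3)nc(-c3ccsc3)c2)cc1`, has not yet been measured. It differs from compound 3 in one place: thiophen-3-yl in place of pyridin-3-yl on an aromatic carbon. Among the compounds with values here, compound 1 also carries a thiophen-3-yl group on its core, though with a hydroxyphenyl group of a different kind, and it gives the lower of the two known numbers. On that slender ground a modest step toward a lower number is expected for compound 4, about the size of a 2.0-fold lower number from compound 3 to compound 4 (0.29 log units; within the scatter), but the gap between the two hydroxyphenyl groups leaves the comparison uncertain. Compound 4 is therefore estimated at 15000 nM, with a range from 6000 nM to 40000 nM.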

Compound 4, half-maximal inhibitory concentration: 5490 nM
For compound 4 the middle estimate is 2.7-fold (0.44 log units) above the measured one, and the stated range ends above it.
By their numbers in this assay, from the lowest: compound 4; then compound 1; then compound 3.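

In this assay the change next to the ring nitrogen of the shared core can now be read directly: thiophen-3-yl in place of pyridin-3-yl gives a 5.3-fold lower number from compound 3 to compound 4 (0.73 log units; beyond the scatter) and so lies beyond the scatter. Within the data shown here, the hydroxyl placement can also be read for the first time, with thiophen-3-yl held fixed, as 4-hydroxyphenyl in place of 3-hydroxyphenyl gives a 2.1-fold lower number from compound 1 to compound 4 (0.32 log units; beyond the scatter) and this too lies beyond the scatter. Both steps end at compound 4, which therefore has the lowest number of the three compounds with values, and both the ring at this position and the placement of the hydroxyl group alter the read-out. Nothing given here bears on why either change acts as it does.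

Among these compounds, compound 2 has no reported number, so no step involving it can be read, and it says nothing about pyridin-4-yl at this position. Going by these compounds, it also remains open whether a plain phenyl or a furan-3-yl group at this position would give a lower number still, and whether 4-hydroxyphenyl would also give a lower number than 3-hydroxyphenyl with pyridin-3-yl in place of thiophen-3-yl.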